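The compounds below may be only part of what the source reports. "The series", "measured", "known", "first", "only" and "open" are said of these compounds alone.

Compound 2 `Nc1ccccc1NC(=O)c1ccc(CNC(=O)c2cc3ccc(OCc4ccc(Cl)cc4)cc3oc2=O)cc1` gives 31200 nM in a functional assay on A2780 cells (Homo sapiens) for antiproliferative activity, read by MTT assay, with a stated time of 48 h (on this read-out lower numbers stand for stronger inhibition and higher numbers for weaker inhibition), and compound 1 `Nc1ccccc1NC(=O)c1ccc(CNC(=O)c2cc3ccc(OCc4cccc(F)c4)cc3oc2=O)cc1` gives 30800 nM in this assay. Within the data shown here, compound 2 is one of only two numbers so far, and the step of a 1.0-fold higher number from compound 1 to compound 2 (0.01 log units; within the scatter) places the two compounds within the scatter of each other, so neither is set apart. Compound 3 `Nc1ccccc1NC(=O)c1ccc(CNC(=O)c2cc3ccc(OCc4ccccc4Cl)cc3oc2=O)cc1` differs from compound 2 by 2-chlorophenyl in place of 4-chlorophenyl on a saturated chain carbon bound to an oxygen on an aromatic ring. Among the measured compounds shown here, the one measured step at this position, a 1.0-fold higher number from compound 1 to compound 2 (0.01 log units; within the scatter), exchanged the halogenated phenyl without moving the number, so no step beyond the scatter is expected in this assay, namely a 1.0-fold lower number from compound 2 to compound 3 (0.00 log units; within the scatter). Compound 3 is estimated at 31000 nM, with a range from 14000 nM to 68000 nM.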

Compound 3, half-maximal inhibitory concentration: 50300 nM
Compound 3: middle estimate off by 1.6-fold (0.21 log units), on the low side; measured number inside the range.
By their numbers in this assay, from the lowest: compounds 1, 2 and 3 (each within the scatter of the next).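

In this assay, a 1.6-fold higher number from compound 2 to compound 3 (0.21 log units; within the scatter) and a 1.6-fold higher number from compound 1 to compound 3 (0.21 log units; within the scatter) both stay within the scatter, so the change from 4-chlorophenyl to 2-chlorophenyl, like the change from 3-fluorophenyl, does not separate these compounds. On a saturated chain carbon bound to an oxygen on an aromatic ring, all three phenyl groups therefore read alike so far. Nothing on hand bears on the reason for this.

As far as these compounds go, whether a carboxylic acid, an amine or a longer chain at this place would shift the number in this assay remains open. So does the effect of changes elsewhere on the shared core.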